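Swapping Chloro for Fluoro on the Pendant Aryl Ring

The source may hold more compounds than are shown below. What is called first, only, known or untested is meant among the compounds shown, and "the series" means these compounds.

Measured compounds:
compound 1 `O=C1/C(=C/c2ccccc2)NS(=O)(=O)c2ccccc21`: 1780 nM
compound 2 `COc1ccc(/C=C2\NS(=O)(=O)c3ccccc3C2=O)cc1`: 1530 nM
compound 3 `O=C1/C(=C/c2ccc(Cl)cc2)NS(=O)(=O)c2ccccc21`: 4350 nM

All three share one core and were measured in an assay for inhibition of Intestinal-type alkaline phosphatase (Homo sapiens), read by spectrophotometry, with stated times of 10 min and 20 min; a higher number here means a weaker inhibitor, a lower number a stronger inhibitor. Compound 3 gives the highest number of the three: the step of a 2.4-fold higher number from compound 1 to compound 3 (0.39 log units; beyond the scatter) and the step of a 2.8-fold higher number from compound 2 to compound 3 (0.45 log units; beyond the scatter) both go beyond the scatter, so compound 3 is the weakest inhibitor shown. Compound 4 `O=C1/C(=C/c2ccc(F)cc2)NS(=O)(=O)c2ccccc21` differs from compound 3 by fluoro in place of chloro on an aromatic carbon. Among the compounds with values here, no measured step exchanges one halogen for another; the only bearing comes from the two modest rises seen on adding chloro. The expectation for compound 4 is therefore a number between those of compound 1 and compound 3, a step of a 1.7-fold lower number from compound 3 to compound 4 (0.22 log units; within the scatter) that may stay within the scatter. Compound 4 is estimated at 2600 nM, with a range from 1200 nM to 5600 nM.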

Compound 4, half-maximal inhibitory concentration: 3060 nM
Compound 4: middle estimate off by 1.2-fold (0.07 log units), on the low side; measured number inside the range.
By their numbers in this assay, from the lowest: compounds 2, 1, 4 and 3 (each within the scatter of the next, the first and the last beyond it).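

Exchanging one halogen for another at this ring position can now be read directly (a 1.4-fold lower number from compound 3 to compound 4 (0.15 log units; within the scatter)), and chloro and fluoro cannot be told apart here. Chloro stood apart from both hydrogen and methoxy, but fluoro does not stand apart from hydrogen (a 1.7-fold higher number from compound 1 to compound 4 (0.24 log units; within the scatter)) or from methoxy (a 2.0-fold higher number from compound 2 to compound 4 (0.30 log units; within the scatter)). No measurement on hand gives a reason for this.

Still open, going by these compounds, is whether an amine or a carboxylic acid at this position would move the number beyond the scatter, and in which direction. The compounds shown also do not say whether bromo would stay with chloro and fluoro.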